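The compounds below may be only part of what the source reports. "The series", "measured", "known", "first", "only" and "open" are said of these compounds alone.

Compound 1 `CCN(Cc1ccoc1)C(=O)COc1ccc(C)cc1`: 136 nM
Compound 2 `Cc1ccc(OCC(=O)N(Cc2cccs2)C2CCCCC2)cc1`: 40000 nM

In an assay on HEK293 cells for agonist activity at transient receptor potential cation channel subfamily M member 8 (Homo sapiens), read by fluorescence and calcium flux, with a stated time of 15 min (on this read-out lower numbers stand for an effect already at smaller amounts and higher numbers for an effect only at larger amounts of compound), compound 2 gives the higher of the two numbers, and the gap to compound 1 is beyond the usual scatter. Compound 3 `CCC(C)N(Cc1cccs1)C(=O)COc1ccc(C)cc1` has not yet been measured. It differs from compound 2 by sec-butyl in place of cyclohexyl on an amide-type nitrogen. For the measured compounds named here, no measured pair shows this exact change, so the size of the step is uncertain. Compound 1, which carries a smaller group on that nitrogen, gives 136 nM in this assay. On that basis a step down is expected for compound 3, a 6.7-fold lower number from compound 2 to compound 3 (0.82 log units; beyond the scatter). The estimate for compound 3 is 6000 nM, in the range 800 nM to 40000 nM.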

Compound 3, half-maximal effective concentration: 2000 nM
Compound 3: the middle estimate sits 3.0-fold (0.48 log units) above what was measured; the measured number falls inside the stated range.
By their numbers in this assay, from the lowest: compound 1; then compound 3; then compound 2.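

In this assay, sec-butyl in place of cyclohexyl on the amide-type nitrogen gives a 20-fold lower number from compound 2 to compound 3 (1.30 log units; beyond the scatter), so this position clearly responds to the group it carries. Both groups are made of carbon only and have no hydrogen-bond donors or acceptors, so a change in the carbon group alone is enough to produce a large step. Nothing here shows why the step is so large. Going by these compounds, it remains open how the number would move with a cyclopentyl ring, a straight butyl chain or a chain ending in an amine on that nitrogen.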